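Compound 2 to compound 4: cytotoxicity notes

The compounds below may be only part of what the source reports. "The series", "measured", "known", "first", "only" and "open" are said of these compounds alone.

Measured in an ADME assay on cells (Homo sapiens) for cytotoxicity, read by polymerase chain reaction, with a stated time of 3 days; a lower number here means that less compound is tolerated, a higher number that more compound is tolerated:
- compound 1 `Nc1nc(Cl)c(-c2ccco2)c(N[C@@H]2C[C@H](CO)[C@@H](O)[C@H]2O)n1`: > 25000 nM
- compound 2 `Nc1nc(Cl)c(-c2cccs2)c(N[C@@H]2C[C@H](CO)[C@@H](O)[C@H]2O)n1`: > 25000 nM
- compound 3 `Nc1nc(Cl)c(-c2nccs2)c(N[C@@H]2C[C@H](CO)[C@@H](O)[C@H]2O)n1`: > 25000 nM

Compound 2 stands at > 25000 nM, which is a limit and not a number. The other two compounds give no number either: the limit of > 25000 nM in this assay, at which 3 of the 3 values shown sit.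

Compound 4 `Nc1nc(Cl)c(-c2nc3ccccc3s2)c(N[C@@H]2C[C@H](CO)[C@@H](O)[C@H]2O)n1` carries 1,3-benzothiazol-2-yl in place of thiophen-2-yl on an aromatic carbon, ortho to a chloro group: 1,3-benzothiazol-2-yl in place of thiophen-2-yl on an aromatic carbon.

Within the data shown here, the steps that bear on this change are a step that the two limits leave unreadable from compound 1 to compound 2, a step that the two limits leave unreadable from compound 1 to compound 3 and a step that the two limits leave unreadable from compound 2 to compound 3. None of them has a readable size, and none brings in a six-membered aromatic ring of carbon only, so the size of this step is poorly constrained. The expectation rests on compound 3, whose limit is > 25000 nM. In this assay, no change beyond the scatter is expected, and the expected step is a number no higher from compound 2 to compound 4 (the limit leaves the size open). Compound 4 is estimated at 25000 nM, with an expected range of 10000 nM to 40000 nM.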

Compound 4, half-maximal cytotoxic concentration: 14000 nM
Compound 4: middle estimate off by 1.8-fold (0.25 log units), on the high side; low and high end bracket the measured number.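

In this assay, among these compounds, compound 4 gives 14000 nM, the first number at this position, whereas the steps among compounds 1, 2 and 3 cannot be read. Bringing in 1,3-benzothiazol-2-yl, with its six-membered aromatic ring of carbon only, gives an at least 1.7-fold lower number from compound 2 to compound 4 (0.25 log units; that floor lies within the scatter), an at least 1.7-fold lower number from compound 3 to compound 4 (0.25 log units; that floor lies within the scatter) and an at least 1.7-fold lower number from compound 1 to compound 4 (0.25 log units; that floor lies within the scatter). Each of these steps is a floor and not a full size, with the other three compounds held at a limit: the limit of > 25000 nM in this assay, at which 3 of the 4 values shown sit.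

The compounds shown leave open how large these steps are and whether the six-membered aromatic ring of carbon only accounts for them. A phenyl group or a 1,3-benzoxazol-2-yl group at this position, on the same core, would help separate the fused ring from the sulfur and nitrogen it carries.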